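A Methyl Group on the Hydroxyethyl Chain

A few compounds are considered here, and "the series" means these few. Any claim that something is new, unique, unknown or untested is made for them only; others in the source may bear on it.

In an ADME assay on THP-1 cells (Homo sapiens) for cytotoxicity, read by flow cytometry and propidium iodide staining, with a stated time of 72 h (a higher number here means a weaker inhibitor, a lower number a stronger inhibitor), compound 1 (`Cc1nc(CS(=O)(=O)c2ccccc2)c([N+](=O)[O-])n1C`) gives > 846000 nM as a limit of the assay, not a number. Compound 2 (`Cc1nc(CS(=O)(=O)c2ccccc2)c([N+](=O)[O-])n1CCO`) gives > 768000 nM as a limit too, so it has no exact value of its own. Compound 3 (`Cc1ccc(S(=O)(=O)Cc2nc(C)n(CCO)c2[N+](=O)[O-])cc1`) gives 59000 nM as a true number.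

Compound 4 (`Cc1nc(CS(=O)(=O)c2ccccc2)c([N+](=O)[O-])n1CC(C)O`) differs from compound 2 on the side chain. The change is methyl in place of hydrogen on a saturated chain carbon bound to an oxygen on a saturated carbon and a saturated chain carbon and so 2-hydroxyethyl becomes 2-hydroxypropyl.

For the measured compounds named here, two measured steps bear on this. The one on the same chain is a step that the two limits leave unreadable from compound 1 to compound 2 and gives no usable size. The other is an at least 13-fold lower number from compound 2 to compound 3 (1.11 log units; beyond the scatter) with its methyl on an aromatic carbon, not on the chain, so it is only a loose guide. A smaller move toward a lower number is expected here, and the result may again be only a limit. The estimate gives an at least 1.9-fold lower number from compound 2 to compound 4 (0.28 log units; that floor lies within the scatter) as the expected step. For compound 4 the estimated value is 400000 nM with an expected range from 80000 nM to 800000 nM in this assay once measured.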

Compound 4, half-maximal inhibitory concentration: 418000 nM
Beside the measured number, compound 4's estimate is 1.0-fold (0.02 log units) below it; measured number inside the range.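

With the 2-hydroxypropyl chain, compound 4 gives a true number in this assay, so this chain position now has a measured point, whereas the step between compound 1 and compound 2 cannot be read. The methyl on the saturated chain carbon gives an at least 1.8-fold lower number from compound 2 to compound 4 (0.26 log units; that floor lies within the scatter), and the whole 1-hydroxyethyl change on the saturated chain carbon bound to an aromatic nitrogen gives an at least 2.0-fold lower number from compound 1 to compound 4 (0.30 log units; that floor lies within the scatter); both floors lie within the scatter, so neither shows a clear shift on its own. The first step stands only as a floor because compound 2 sits at a limit: the limit of > 768000 nM in this assay, at which 1 of the 4 values shown sits.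

From the compounds shown here alone, it remains open how this position responds to a longer chain, or to an amine in place of the hydroxyl. Also open is how the chain methyl behaves together with the methyl on the aromatic carbon of compound 3; no compound shown carries both.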